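The source may hold more compounds than are shown below. What is called first, only, known or untested is meant among the compounds shown, and "the series" means these compounds.

In a functional assay on cells (Homo sapiens) for antiproliferative activity, read by CellTiter-Glo, with a stated time of 96 h (a lower number here means a stronger inhibitor, a higher number a weaker inhibitor), compound 1 (`COc1ccc(-c2nsc3c2NC(=O)CC3c2cccc(Cl)c2)cc1`) gives > 2000 nM, a limit and not a number. Among the compounds with values here, compound 2 (`COc1ccc(-c2nsc3c2NC(=O)CC3c2cccc(F)c2)cc1`) gives > 2000 nM, likewise a limit, and the series so far is the limit of > 2000 nM in this assay, at which 2 of the 2 values shown sit. Within the data shown here, the one measured step bearing on the change is a step that the two limits leave unreadable from compound 1 to compound 2, so it offers no size to carry forward. Compound 3 (`COc1ccc(-c2nsc3c2NC(=O)CC3c2ccsc2)cc1`) differs by thiophen-3-yl in place of 3-fluorophenyl on a saturated ring carbon. No step beyond the scatter is expected in this assay, and no direction can be favoured. The step expected is a step that the limit leaves unreadable from compound 2 to compound 3. Compound 3 is estimated at 3000 nM, with an expected range of 1000 nM to 10000 nM.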

Compound 3, half-maximal inhibitory concentration: 309 nM
Estimate against measurement, compound 3: 9.7-fold (0.99 log units) above, and the stated range ends above it.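

In this assay, the saturated ring carbon now proves able to move the read-out, which the two halogen-bearing phenyl compounds could not show. Thiophen-3-yl in place of 3-fluorophenyl gives an at least 6.4-fold lower number from compound 2 to compound 3 (0.81 log units; beyond the scatter), and in place of 3-chlorophenyl it gives an at least 6.4-fold lower number from compound 1 to compound 3 (0.81 log units; beyond the scatter). Only compound 3 gives a value off the limit: the limit of > 2000 nM in this assay, at which 2 of the 3 values shown sit.

Going by these compounds, the step between compound 1 and compound 2 cannot be read, so any effect of the halogen on that phenyl stays unknown. Also open, on these data alone, is whether thiophen-2-yl, a pyridine ring or unsubstituted phenyl at this carbon would match thiophen-3-yl.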